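The source may report more compounds than this note shows. Statements on the series, on what has been measured and on what is new or still open speak of the compounds shown alone.

Compound 1 `CCCn1c(=O)[nH]c2nc(-c3ccc(S(=O)(=O)N4CCN(c5ccc(F)cc5)CC4)cc3)[nH]c2c1=O`: > 1000 nM
Compound 2 `CCCn1c(=O)[nH]c2nc(-c3ccc(S(=O)(=O)N4CCN(c5ccc(Cl)cc5F)CC4)cc3)[nH]c2c1=O`: > 1000 nM
Compound 3 `CCCn1c(=O)[nH]c2nc(-c3ccc(S(=O)(=O)N4CCN(c5ccccc5C)CC4)cc3)[nH]c2c1=O`: > 1000 nM

The three measured compounds share one core and differ only in the aryl group on an amine nitrogen in a ring. In an assay on CHO cells for displacement of a labelled ligand from adenosine receptor A3 (Homo sapiens), read by scintillation counting, with a stated time of 45 min, in the presence of a further agent that is not named here (a lower number here means a stronger inhibitor, a higher number a weaker inhibitor), compound 1 is reported only as a limit, > 1000 nM. Compound 2 likewise reaches only a limit, > 1000 nM. Compound 3 too stands at a limit, > 1000 nM, and so no number places it against the other two. The steps a step that the two limits leave unreadable from compound 1 to compound 2, a step that the two limits leave unreadable from compound 1 to compound 3 and a step that the two limits leave unreadable from compound 2 to compound 3 therefore cannot be sized, because the limit of > 1000 nM in this assay, at which 3 of the 3 values shown sit, covers every value shown.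

Compound 4 `CCCn1c(=O)[nH]c2nc(-c3ccc(S(=O)(=O)N4CCN(C)CC4)cc3)[nH]c2c1=O` carries the change (methyl in place of 2-methylphenyl on an amine nitrogen in a ring). Within the data shown here, none of the measured steps bears on this change in a readable way; all three only say that the aryl piperazines fail to reach a measurable inhibition constant. With nothing pointing to a gain, compound 4 is expected to remain at or near the same limit. The estimated step is a step that the limit leaves unreadable from compound 3 to compound 4. Compound 4 is thus expected to give about 3000 nM in this assay, with a range from 500 nM to 30000 nM, and most likely it will again be reported only as a limit.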

Compound 4, inhibition constant: > 1000 nM
Compound 4: no number, only a limit (the forecaster's own chance of this, stated with the estimate: 75%); the middle value is on the limit's open side.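

In this assay compound 4 gives > 1000 nM, which is a limit and not a number. Its steps from compound 1, compound 2 and compound 3 cannot be read, because all the values stop at the same point: the limit of > 1000 nM in this assay, at which 4 of the 4 values shown sit.

The compounds shown leave open whether any group on this amine nitrogen in a ring would give a measurable inhibition constant.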